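This account rests on a few compounds, and the source may have more. Where it says the series, first, only, none or still open, it means among the compounds named here.

In a physicochemical assay for solubility, read by HPLC, in phosphate buffer, measured as kinetic solubility, with a stated time of 1 h, at pH 7.4, tested at 250 uM (a lower number here means a less soluble compound, a higher number a more soluble compound), compound 1 `CC(C)N1CCC(c2ccc3c(c2)oc(=O)n3C(=O)NCCCCc2ccccc2)CC1` gives 50000 nM. Compound 2 `CC(=O)N1CCC(c2ccc3c(c2)oc(=O)n3C(=O)NCCCCc2ccccc2)CC1` gives < 1000 nM, which is a limit of the assay and not a number. For the measured compounds named here, the only measured step is large: an at least 50-fold lower number from compound 1 to compound 2 (1.69 log units; beyond the scatter), with acetyl in place of isopropyl on an amine nitrogen in a ring. Compound 3 `CN1CCC(c2ccc3c(c2)oc(=O)n3C(=O)NCCCCc2ccccc2)CC1=O` carries 1-methyl-2-oxopiperidin-4-yl in place of 1-acetylpiperidin-4-yl on an aromatic carbon. That measured step concerns a different exchange and bears only indirectly, and both groups here have no net charge. The expected step is a step that the limit leaves unreadable from compound 2 to compound 3, with no change beyond the scatter anticipated in this assay. Compound 3 is estimated at 800 nM, with an expected range of 200 nM to 4000 nM.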

Compound 3, solubility: 20000 nM
Compound 3: middle estimate off by 25-fold (1.40 log units), on the low side, outside the stated range (above it).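

At this aromatic carbon, two groups with no net charge and the same donor and acceptor counts separate widely in this assay, with an at least 20-fold higher number from compound 2 to compound 3 (1.30 log units; beyond the scatter). The 1-methyl-2-oxopiperidin-4-yl group stays much nearer the isopropyl-bearing compound, with a 2.5-fold lower number from compound 1 to compound 3 (0.40 log units; beyond the scatter), so the large drop seen with the acetyl group does not extend to every uncharged piperidine carbonyl variant shown. The reading for compound 2 is a limit of the assay and not a number: the limit of < 1000 nM in this assay, at which 1 of the 3 values shown sits.

Going by these compounds, the true size of that step stays open. So does the result for a free piperidine amine or a carboxylic acid on this aromatic carbon.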